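The compounds below may be only part of what the source reports. "The series", "measured", "known", "first", "only" and "open" are said of these compounds alone.

Measured so far in a functional assay on PC-3 cells (Homo sapiens) for antiproliferative activity, read by CCK-8 assay, with a stated time of 6 days; on this read-out higher numbers stand for weaker inhibition and lower numbers for stronger inhibition:
compound 1 `N#Cc1ccc(N2CCCc3c(-c4cccnc4)cccc32)cc1C(F)(F)F` gives 7970 nM
compound 2 `CCN(c1ccc(C#N)c(Cl)c1)c1cc(-n2cnc3ccccc32)ccc1C` gives 8160 nM
compound 3 `Cn1nccc1-c1cccc2c1CCCN2c1ccc(C#N)c(C(F)(F)F)c1` gives 9800 nM

The three numbers in this assay cannot be told apart: the gap from compound 2 to compound 1 and the gap from compound 2 to compound 3 both lie within the usual scatter, so compound 2 stands level with the other two.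

Compound 4 `CCN(c1ccc(C#N)c(Cl)c1)c1cc(-c2c[nH]nc2C)ccc1C` is the unmeasured analogue of compound 2. The change is 3-methyl-1H-pyrazol-4-yl in place of 1H-benzimidazol-1-yl on an aromatic carbon.

Among the compounds with values here, only one measured step compares two small aromatic substituents, a 1.2-fold higher number from compound 1 to compound 3 (0.09 log units; within the scatter), and it is on a different core and within the scatter. Within the data shown here, no step swaps a 1H-benzimidazol-1-yl for a 3-methyl-1H-pyrazol-4-yl, so nothing in hand supports a shift in either direction for compound 4. The expectation is therefore a step of a 1.1-fold higher number from compound 2 to compound 4 (0.04 log units; within the scatter), that is none beyond the scatter. Compound 4 is estimated at 9000 nM, within a range of 4000 nM to 20000 nM in this assay.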

Compound 4, half-maximal inhibitory concentration: 9030 nM
For compound 4 the middle estimate is 1.0-fold (0.00 log units) below the measured one, and the stated range covers the measured number.
By their numbers in this assay, from the lowest: compounds 1, 2, 4 and 3 (each within the scatter of the next).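

In this assay, replacing 1H-benzimidazol-1-yl on the aromatic carbon meta to a large group and para to a methyl group gives a 1.1-fold higher number from compound 2 to compound 4 (0.04 log units; within the scatter). Within the data shown here, this is the first reading at this position on the core of compound 2, and it shows that going from a two-ring group of 9 heavy atoms to a one-ring group of 6, with a hydrogen-bond donor gained, leaves the number within the scatter. No measurement at hand accounts for this lack of separation.

The compounds shown leave open whether any group at this carbon can move the number beyond the scatter, since all of them so far are aromatic rings. A non-aromatic group there, such as an amine or a carboxylic acid, would test this.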